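Nitro for cyano on two cores in the antiproliferative series

A few compounds are considered here, and "the series" means these few. Any claim that something is new, unique, unknown or untested is made for them only; others in the source may bear on it.

In a functional assay on VCaP cells (Homo sapiens) for antiproliferative activity, read by propidium iodide staining, with a stated time of 96 h (on this read-out higher numbers stand for weaker inhibition and lower numbers for stronger inhibition), compound 1 `CC(O)(COc1cccc(S(F)(F)(F)(F)F)c1)C(=O)Nc1ccc(C#N)cc1C(F)(F)F` gives 10300 nM. Compound 2 `CC(O)(COc1cccc(S(F)(F)(F)(F)F)c1)C(=O)Nc1ccc([N+](=O)[O-])cc1C(F)(F)F` carries nitro in place of cyano on an aromatic carbon and gives 20300 nM; the step is a 2.0-fold higher number from compound 1 to compound 2 (0.29 log units; within the scatter). Compound 3 `CC(O)(CS(=O)(=O)c1cccc(S(F)(F)(F)(F)F)c1)C(=O)Nc1ccc(C#N)cc1C(F)(F)F` gives 20800 nM in this assay; the difference between its core and the core of compound 1 is not broken down here, but compound 3 gives a higher number than compound 1, while the values of compound 3 and compound 2 lie within the scatter of each other. Within the data shown here, compound 4 `CC(O)(CS(=O)(=O)c1cccc(S(F)(F)(F)(F)F)c1)C(=O)Nc1ccc([N+](=O)[O-])cc1C(F)(F)F` is not yet measured; it carries nitro in place of cyano on an aromatic carbon, the same change as the one between compound 1 and compound 2, made on the core of compound 3. Because the earlier instance of this change was a 2.0-fold higher number from compound 1 to compound 2 (0.29 log units; within the scatter), a step of similar size is expected here, a 1.8-fold higher number from compound 3 to compound 4 (0.26 log units; within the scatter). Compound 4 is accordingly estimated at 38000 nM in this assay. The expected range for compound 4 runs from 19000 nM to 80000 nM. A number this weak may be reported only as a limit of the assay rather than a figure.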

Compound 4, half-maximal inhibitory concentration: 100000 nM
Compound 4: the middle estimate sits 2.6-fold (0.42 log units) below what was measured; the whole stated range lies below it.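

Nitro in place of cyano on an aromatic carbon, carried to the sulfonyl-linked core, gives a 4.8-fold higher number from compound 3 to compound 4 (0.68 log units; beyond the scatter) in this assay, so the number rises on both cores shown, and on this core the step lies beyond the scatter. Set side by side, the two steps cannot be told apart: the same change on two cores in this assay, a 2.0-fold higher number (0.29 log units; within the scatter) from compound 1 to compound 2 and a 4.8-fold higher number (0.68 log units; beyond the scatter) from compound 3 to compound 4, 2.4-fold (0.39 log units) apart, within the scatter of two such steps. Among these compounds, the notes therefore support carrying the change over as a step in the same direction, but they do not show that its size depends on the core, and with only two pairs, one of them within the scatter, they do not establish a general rule for the series.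

Still open, going by these compounds, is whether other groups at this position, such as an amine, a carboxylic acid or a chlorine atom, would follow the same course on the two cores. On these data alone, it is also open whether the step between cyano and nitro would hold on a core in which the trifluoromethyl group is replaced by a methyl group.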